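The source may report more compounds than this note shows. Statements on the series, on what has been measured and on what is new or still open speak of the compounds shown alone.

Notes on the series: in a functional assay on PC-3 cells (Homo sapiens) for cytotoxicity, read by MTT assay, with a stated time of 72 h (on this read-out lower numbers stand for stronger inhibition and higher numbers for weaker inhibition), compound 1 `Cc1cc(NC(C)C)nc(SCc2nc3ccccc3[nH]2)n1` gives only a limit, > 100000 nM. Compound 2 `Cc1cc(NCCO)nc(SCc2nc3ccccc3[nH]2)n1` likewise returns only a limit in this assay, > 100000 nM. Compound 3 `Cc1cc(N2CCNCC2)nc(SCc2nc3ccccc3[nH]2)n1` also returns only a limit in this assay, > 100000 nM, so compound 3 has no readable place among the numbers shown. The steps a step that the two limits leave unreadable from compound 1 to compound 2, a step that the two limits leave unreadable from compound 1 to compound 3 and a step that the two limits leave unreadable from compound 2 to compound 3 cannot be sized, since (the limit of > 100000 nM in this assay, at which 3 of the 3 values shown sit). Compound 4 `Cc1cc(NNC(N)=S)nc(SCc2nc3ccccc3[nH]2)n1` carries a group of 5 heavy atoms (1 carbon, 3 nitrogen, 1 sulfur; no ring) in place of a group of 6 heavy atoms (4 carbon, 2 nitrogen; one six-membered non-aromatic ring with 2 hetero atoms), on an aromatic carbon. The two steps into compound 3 bear on this change, yet neither gives a size or direction, so the expected step of a number no higher from compound 3 to compound 4 (the limit leaves the size open) is set at none beyond the scatter. Compound 4 is therefore estimated at 100000 nM, within 30000 nM to 300000 nM, and most likely again reported only as a limit.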

Compound 4, half-maximal inhibitory concentration: > 100000 nM
Compound 4: a limit, no number; the forecaster's own chance of this, stated with the estimate: 80%; the middle value lies on the limit itself.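

Compound 4 adds no readable step against compound 1, compound 2 or compound 3 in this assay, because all four compounds return only a limit: the limit of > 100000 nM in this assay, at which 4 of the 4 values shown sit.

The compounds shown leave open whether any group on this aromatic carbon of the shared core gives a readable number.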